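The source may hold more compounds than are shown below. What is called first, only, known or untested is meant among the compounds shown, and "the series" means these compounds.

Measured so far in an assay on CHO-K1 cells for displacement of a labelled ligand from Alpha-1D adrenergic receptor (Homo sapiens), read by scintillation counting, with a stated time of 60 min; on this read-out lower numbers stand for stronger inhibition and higher numbers for weaker inhibition:
- compound 1 `N=c1c(C(N)=O)cc(Cl)cn1Cc1ccccc1` gives 30 nM
- compound 2 `N=c1c(C(N)=O)cc(Cl)cn1-c1ccccc1` gives > 940 nM in this assay, which is a limit of the assay and not a number
- compound 3 `N=c1c(C(N)=O)cc(Cl)cn1Cc1ccco1` gives 160 nM in this assay

Compound 3 holds the highest of the two numbers recorded in this assay; its nearest neighbour is compound 1, and the step is a 5.3-fold higher number from compound 1 to compound 3 (0.73 log units; beyond the scatter). Compound 2 is known only by its limit (the limit of > 940 nM in this assay, at which 1 of the 3 values shown sits). Compound 4 `N=c1c(C(N)=O)cc(Cl)cn1Cc1cccnc1` is not yet measured in this assay. It differs from compound 3 by pyridin-3-yl in place of furan-2-yl on a saturated chain carbon bound to an aromatic nitrogen. Among the compounds with values here, the only measured step that bears on this change is the one from compound 1 to compound 3, where a six-membered aromatic ring on the saturated chain carbon was swapped for a five-membered one and the number rose beyond the scatter. Within the data shown here, compound 4 restores a six-membered ring, now with one hetero atom, at the same place, so the expectation is that the number moves back down toward that of compound 1, though not necessarily all the way, since no measured pair tells how a ring nitrogen in this ring is tolerated. The expected step is a 2.3-fold lower number from compound 3 to compound 4 (0.36 log units; beyond the scatter). Compound 4 is therefore estimated at 70 nM in this assay, within a range of 25 nM to 250 nM.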

Compound 4, inhibition constant: 250 nM
Compound 4: middle estimate off by 3.6-fold (0.55 log units), on the low side; the measured number falls inside the stated range.
By their numbers in this assay, from the lowest: compound 1; then compounds 3 and 4 (each within the scatter of the next). At a limit, above all of these: compound 2.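

In this assay, ring size alone does not decide the outcome on a saturated chain carbon bound to an aromatic nitrogen: the change from furan-2-yl, a five-membered aromatic ring, to pyridin-3-yl, a six-membered one, gives a 1.6-fold higher number from compound 3 to compound 4 (0.19 log units; within the scatter), so these two groups cannot be told apart here. A six-membered aromatic ring at this place is therefore not enough to match phenyl, since the change from phenyl to pyridin-3-yl gives an 8.3-fold higher number from compound 1 to compound 4 (0.92 log units; beyond the scatter), and among the three groups at this place, both rings that carry a hetero atom now stand beyond the scatter from phenyl in compound 1. The measurements shown give no cause for either step.

Still open, from the compounds shown here alone, is whether thiophen-2-yl or pyridin-4-yl on the same chain carbon would fall with compound 1 or with compounds 3 and 4, which would test how far the result holds for other rings that carry a hetero atom. Also open, going by these compounds, is how a longer chain, such as 2-phenylethyl, or a methoxy group on the phenyl ring of compound 1 would read in this assay.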